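Ring Size at the Amide Carbonyl of a Pyrrolidine Oxadiazole Series

A few compounds are considered here, and "the series" means these few. Any claim that something is new, unique, unknown or untested is made for them only; others in the source may bear on it.

Measured so far in an in vitro functional assay on HEK293-A cells for positive allosteric modulation of metabotropic glutamate receptor 5 (Homo sapiens), read by fluorescence and calcium flux, with a stated time of 140 s; on this read-out higher numbers stand for an effect only at larger amounts of compound and lower numbers for an effect already at smaller amounts:
compound 1 `O=C(C1CC1)N1CCCC1c1nc(-c2cccc(F)c2)no1` gives 2900 nM
compound 2 `O=C(C1CCCC1)N1CCCC1c1nc(-c2cccc(F)c2)no1` gives 1000 nM

Within the data shown here, compound 2 stands at the lower of the two numbers, and its only neighbour is compound 1, which sits at a higher number. Among the measured compounds shown here, the one step available, a 2.9-fold lower number from compound 1 to compound 2 (0.46 log units; beyond the scatter), shows that enlarging the carbocycle on the carbonyl carbon from cyclopropyl to cyclopentyl lowered the number by a modest amount, clearly beyond the scatter.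

Compound 3 `O=C(C1CCCCC1)N1CCCC1c1nc(-c2cccc(F)c2)no1` continues along the same line: cyclohexyl in place of cyclopentyl on a carbonyl carbon. For the measured compounds named here, this is the only kind of change the two measured compounds speak to, and they speak to it in one direction only, through the step from compound 1 to compound 2. Whether a further enlargement carries on that trend or levels off cannot be read from a single step, so the expected step is set smaller than the measured one. Compound 3 is therefore expected to give 600 nM, within 250 nM to 2000 nM, a change from compound 2 of a 1.7-fold lower number from compound 2 to compound 3 (0.22 log units; within the scatter) that is estimated to be close to the edge of the scatter.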

Compound 3, half-maximal effective concentration: 10000 nM
For compound 3 the middle estimate is 17-fold (1.22 log units) below the measured one, outside the stated range (above it).
By their numbers in this assay, from the lowest: compound 2; then compound 1; then compound 3.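

In this assay, the trend suggested by the earlier pair does not continue: a 2.9-fold lower number from compound 1 to compound 2 (0.46 log units; beyond the scatter) is followed by a 10-fold higher number from compound 2 to compound 3 (1.00 log units; beyond the scatter), so the number at this position does not move in one direction as the carbocycle on the carbonyl carbon grows. The cyclohexyl group also ends up on the far side of the smallest ring, with a 3.4-fold higher number from compound 1 to compound 3 (0.54 log units; beyond the scatter), which places cyclopentyl at the lowest number of the three and shows that replacing a five-membered ring of carbon with a six-membered one is enough to reverse the earlier gain. Nothing available gives a measured reason for this turn in the series.

Among these compounds, with only three ring sizes, it remains open how the numbers run around cyclopentyl, for example with cyclobutyl or cycloheptyl, or with an open-chain group such as isopropyl or tert-butyl on the same carbonyl carbon. Going by these compounds, it is also open whether a ring containing oxygen, such as tetrahydropyranyl, would follow cyclohexyl, and whether the same order of ring sizes holds when the fluorophenyl group of the shared core is replaced by another aryl group.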